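The source may report more compounds than this note shows. Statements on the series, on what has been measured and on what is new or still open speak of the compounds shown alone.

Measured so far:
- compound 1, `COc1cc(OC)c(C(=O)c2ccccc2Br)c(O)c1CN1CCCCC1`, gives 98% in a functional assay on THP-1 cells (Homo sapiens) for inhibition, read by ELISA, with stated times of 30 min and 24 h, tested at 10 uM; on this read-out higher numbers stand for a stronger effect at the one concentration tested and lower numbers for a weaker effect
- compound 2, `COc1cc(OC)c(C(=O)c2cccc(Cl)c2)c(O)c1CN1CCCC1`, gives 81% in this assay

Going by the values given here, of these two numbers, compound 2 stands lowest; the only neighbour is compound 1, whose number lies higher by a gap beyond the usual scatter, so the two compounds are genuinely distinguishable on this read-out.

Compound 3, `COc1cc(OC)c(C(=O)c2ccccc2Br)c(O)c1CN1CCCC1`, has not yet been measured. It departs from compound 2 in a single place: 2-bromophenyl in place of 3-chlorophenyl on a carbonyl carbon. Among the compounds with values here, no measured pair shows this exact exchange on its own, so the size of the step is not yet known from the numbers themselves.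

For compound 3 a modest upward step from compound 2 is expected, on the order of a number 9 percentage points higher from compound 2 to compound 3 (within the scatter), since compound 1 already reaches 98% and shows that higher readings are possible in this assay. Compound 3 is therefore estimated at 90%, with a plausible range from 75% to 100%.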

Compound 3, a percentage reported as activity, at one concentration (the size of the read-out at that concentration, not a potency): 100%
Beside the measured number, compound 3's estimate is 10 percentage points below it; low and high end bracket the measured number.
By their numbers in this assay, from the lowest: compound 2; then compounds 1 and 3 (each within the scatter of the next).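

Going by these compounds alone, with the pyrrolidin-1-yl group held constant, placing 2-bromophenyl instead of 3-chlorophenyl on the carbonyl carbon gives a number 19 percentage points higher from compound 2 to compound 3 (beyond the scatter) in this assay, the first single-place change here to show a clear difference. Placing pyrrolidin-1-yl instead of piperidin-1-yl on the saturated chain carbon gives a number 2 percentage points higher from compound 1 to compound 3 (within the scatter), so with 2-bromophenyl present, this read-out does not separate these two groups. No available evidence bears on the reason for either result.

Because the halogen and its ring position changed together, these compounds cannot show whether bromine, its position, or both matter; 2-chlorophenyl or 3-bromophenyl would separate those possibilities. On these data alone, whether the amine position also tolerates morpholin-4-yl or an open-chain dimethylamino group remains open, as does how compounds 1 and 3 differ at lower concentrations.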